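Trimming One Hydroxy From the Sugar Ring

The compounds below may be only part of what the source reports. "The series", "measured", "known", "first", "only" and "open" are said of these compounds alone.

Measured compounds:
compound 1 `COC(=O)CCSSc1ccccc1/C=N/NC(=O)c1ccccc1` gives 12000 nM
compound 2 `O=C(CCSSc1ccccc1/C=N/NC(=O)c1ccccc1)OC[C@H]1OC(O)[C@H](O)[C@@H](O)[C@@H]1O` gives 17000 nM

Both compounds were tested in a functional assay on MDA-MB-231 cells (Homo sapiens) for antiproliferative activity, read by MTT assay, with a stated time of 72 h; on this read-out higher numbers stand for weaker inhibition and lower numbers for stronger inhibition. In this assay compound 1 gives 12000 nM, and compound 2 gives 17000 nM. Compound 2 stands at one end of a pair whose two numbers cannot be separated, since a 1.4-fold higher number from compound 1 to compound 2 (0.15 log units; within the scatter). In other words, attaching the whole sugar ring to the ester end of compound 1 left the read-out essentially unchanged.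

Compound 3 `O=C(CCSSc1ccccc1/C=N/NC(=O)c1ccccc1)OC[C@H]1OC(O)C[C@@H](O)[C@@H]1O` is the next compound to be measured. Its change is hydrogen in place of hydroxy on a saturated ring carbon, a single oxygen lost from the sugar ring of compound 2.

Among the compounds with values here, only one measured step bears on this, and only loosely: attaching the entire sugar ring produced no step beyond the scatter. Removing a single hydroxy from that ring is a far smaller alteration of the same distant region, so no step beyond the scatter is expected here either; compound 3 is expected to give a 1.1-fold lower number from compound 2 to compound 3 (0.05 log units; within the scatter).

Compound 3 is therefore estimated at 15000 nM, with a range of 7000 nM to 35000 nM.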

Compound 3, half-maximal inhibitory concentration: 22000 nM
The estimate for compound 3 lay 1.5-fold (0.17 log units) below the measured number, within the range that was stated.
By their numbers in this assay, from the lowest: compounds 1, 2 and 3 (each within the scatter of the next).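

In this assay, hydrogen in place of hydroxy on this saturated ring carbon gives a 1.3-fold higher number from compound 2 to compound 3 (0.11 log units; within the scatter), so the sugar ring tolerates losing this one hydroxy without a change that can be told from the scatter. Even the ring with one hydroxy fewer, set against compound 1, which carries no ring at all, gives a 1.8-fold higher number from compound 1 to compound 3 (0.26 log units; within the scatter), which means that both forms of the ring, full and trimmed, remain inseparable from the ringless ester on this read-out. No measurement at hand accounts for this result.

As far as these compounds go, these compounds test only hydrogen at this ring carbon, so it remains open what an amine or a fluorine in the same place would do, and whether the hydroxy groups on the two ring atoms next to it can be exchanged just as freely. Within the data shown here, also open is whether a carboxylic acid or a longer chain at the ester end would move the read-out beyond the scatter, given that every step so far at this end of the molecule has stayed within it.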